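The source may report more compounds than this note shows. Statements on the series, on what has been measured and on what is new or still open speak of the compounds shown alone.

Compound 1 `O=C(Nc1ccc(C(F)(F)F)cc1)C1CCc2ccccc2N1` and compound 2 `CCCC(=O)N1c2ccccc2CCC1C(=O)Nc1cc(C(F)(F)F)cc(C(F)(F)F)c1` were both tested in a functional assay on NUGC-3 cells (Homo sapiens) for cytotoxicity, read by sulforhodamine B assay, with a stated time of 72 h; on this read-out lower numbers stand for stronger inhibition of growth and higher numbers for weaker inhibition of growth. Compound 1 gives 18600 nM, the higher of the two numbers, while compound 2 gives 14400 nM, a gap that lies within the scatter of repeated runs, so neither can be called the more potent. Compound 3 `O=C(Nc1ccc(O)cc1)C1CCc2ccccc2N1` has not yet been measured. It differs from compound 1 by hydroxy in place of trifluoromethyl on an aromatic carbon. Within the data shown here, no measured pair shows this change, so only a modest step from compound 1 to compound 3 is expected, in either direction or none beyond the scatter. The expected step is a 1.3-fold higher number from compound 1 to compound 3 (0.13 log units; within the scatter). For compound 3 the estimate in this assay is 25000 nM, within 8000 nM to 80000 nM.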

Compound 3, concentration for 50% growth inhibition: > 100000 nM
Compound 3 gave a limit, no number; the forecaster's own chance of this, stated with the estimate: 20%; at least 4.0-fold (0.60 log units) between middle value and limit.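

Among these compounds, until now, no measured pair had tested this position. In this assay, putting hydroxy in place of trifluoromethyl on this aromatic carbon, para to a large group, gives an at least 5.3-fold higher number from compound 1 to compound 3 (0.73 log units; beyond the scatter), so growth inhibition depends on the group that sits here. For compound 3 the result is a limit, not a number: the limit of > 100000 nM in this assay, at which 1 of the 3 values shown sits.

From the compounds shown here alone, how large the true step is remains open, and a single swap cannot show which feature of trifluoromethyl matters. Going by these compounds, whether chlorine, a methoxy group or an amine at this place would keep the growth inhibition of compound 1 is also open.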